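Amino Gives Way to Methoxy at the Assay Limit

The source may report more compounds than this note shows. Statements on the series, on what has been measured and on what is new or still open speak of the compounds shown alone.

In a functional assay on HL-60 cells (Homo sapiens) for antiproliferative activity, read by XTT assay, with a stated time of 72 h (on this read-out higher numbers stand for weaker inhibition and lower numbers for stronger inhibition), compound 1 `Nc1nc(N)c2c(-c3ccsc3)cn([C@@H]3O[C@H](CO)[C@@H](O)[C@H]3O)c2n1` gives > 20000 nM, which is a limit and not a number. Compound 2 `Nc1nc(N)c2c(-c3cc4ccccc4o3)cn([C@@H]3O[C@H](CO)[C@@H](O)[C@H]3O)c2n1` gives > 15000 nM, also a limit. Compound 3 `Cc1nc(N)c2c(-c3ccsc3)cn([C@@H]3O[C@H](CO)[C@@H](O)[C@H]3O)c2n1` gives > 20000 nM, again a limit. So compound 1 has no exact value, and neither do the two compounds it can be compared with.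

Compound 4 `COc1nc(N)nc2c1c(-c1ccsc1)cn2[C@@H]1O[C@H](CO)[C@@H](O)[C@H]1O` carries methoxy in place of amino on an aromatic carbon.

The closest measured change is a step that the two limits leave unreadable from compound 1 to compound 3, where methyl replaces amino on an aromatic carbon. The other is a step that the two limits leave unreadable from compound 1 to compound 2, where 1-benzofuran-2-yl replaces thiophen-3-yl. Neither has a readable size, so neither offers a firm guide, and no step beyond the usual scatter is expected in this assay.

The expected step is a number no higher from compound 1 to compound 4 (the limit leaves the size open), with no clear direction. Compound 4 is estimated at 20000 nM, with an expected range of 8000 nM to 30000 nM.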

Compound 4, half-maximal inhibitory concentration: > 20000 nM
Compound 4: a limit, no number (the forecaster's own chance of this, stated with the estimate: 85%); the middle value sits exactly at the limit.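

Compound 4 gives > 20000 nM, which is a limit and not a number. Compound 1 also has only a limit, and no step can be read from compound 1 to compound 4. The compounds shown leave open whether swapping amino for methoxy changes inhibition at all.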